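Bromo Added Beside the Methylsulfanyl Group

A few compounds are considered here, and "the series" means these few. Any claim that something is new, unique, unknown or untested is made for them only; others in the source may bear on it.

The two oxazoles measured so far share a core that carries a trimethoxyphenyl-type ring on one side and a second substituted benzene ring on the other. Compound 1, `COc1cc(-c2ocnc2-c2cc(OC)c(OC)c(OC)c2)ccc1SC`, gives 1480 nM in a functional assay on SK-OV-3 cells (Homo sapiens) for cytotoxicity, read by MTT assay, with a stated time of 48 h (on this read-out lower numbers stand for stronger inhibition and higher numbers for weaker inhibition), the highest of the two numbers recorded and therefore the weaker of the pair. Compound 2, `COc1ccc(-c2ocnc2-c2cc(Br)c(OC)c(OC)c2)cc1OC`, gives 260 nM in this assay, a lower number by a margin that lies beyond the usual scatter; the two structures differ in more than one place, so only the two values themselves can be compared.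

Compound 3, `COc1cc(-c2ncoc2-c2cc(Br)c(SC)c(OC)c2)cc(OC)c1OC`, has not yet been measured. It departs from compound 1 by a single change, (bromo in place of hydrogen on an aromatic carbon), placed ortho to the methylsulfanyl group and meta to a methoxy group. Because compound 2, which also carries bromo, gives 260 nM, a move toward lower numbers is expected for compound 3, and the step of a 3.7-fold lower number from compound 1 to compound 3 (0.57 log units; beyond the scatter) is estimated to lie beyond the scatter. On that basis compound 3 is expected to give about 400 nM, within a range from 150 nM to 1100 nM.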

Compound 3, half-maximal inhibitory concentration: > 20000 nM
Compound 3 ended at the assay's limit; the forecaster's own chance of this, stated with the estimate: 2%; at least 50-fold (1.69 log units) between middle value and limit.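

In this assay compound 3 gives > 20000 nM, which is a limit of the assay and not a number: the limit of > 20000 nM in this assay, at which 1 of the 3 values shown sits. Bromo in place of hydrogen on an aromatic carbon, ortho to the methylsulfanyl group and meta to a methoxy group, brings an at least 13-fold higher number from compound 1 to compound 3 (1.13 log units; beyond the scatter), the first single-place comparison in the series, and it shows that at this position the change goes toward weaker inhibition by a large margin. Compound 2 also carries bromo and gives 260 nM, but it differs from compound 3 in more than one place, so the presence of bromo in compound 2 says nothing about what bromo does at this position.

The compounds shown leave open whether this large step belongs to bromo itself or would also follow from another group in the same place, such as chloro, methyl or an amine. They also leave open whether bromo would give a step of similar size if a methoxy group stood in place of the methylsulfanyl group.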